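Methoxy Added to Compound 2: What One Earlier Step Suggests

A few compounds are considered here, and "the series" means these few. Any claim that something is new, unique, unknown or untested is made for them only; others in the source may bear on it.

Of the compounds shown here, three have so far been tested in a functional assay on SW-620 cells (Homo sapiens) for inhibition, read by sulforhodamine B assay, with a stated time of 48 h; on this read-out lower numbers stand for stronger inhibition of growth and higher numbers for weaker inhibition of growth. Compound 1 `COc1ccc(-c2[nH]c3ccccc3c2/C=C(\C#N)S(=O)(=O)c2ccccc2)cc1` gives 506 nM, and compound 3 `COc1ccc(-c2[nH]c3ccc(OC)cc3c2/C=C(\C#N)S(=O)(=O)c2ccccc2)cc1` gives 540 nM. The two differ by a single change, (methoxy in place of hydrogen on an aromatic carbon), and the move a 1.1-fold higher number from compound 1 to compound 3 (0.03 log units; within the scatter), so this change left the growth inhibition essentially unaltered. Compound 2 `COc1ccc2[nH]c(-c3ccccc3)c(C=C(C#N)C#N)c2c1` gives 3600 nM, the highest of the three numbers, and its gaps to compound 1 and compound 3 both lie beyond the scatter. The difference between the core of compound 2 and the core of compound 1 is not broken down here.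

The untested compound 4 `COc1ccc(-c2[nH]c3ccc(OC)cc3c2C=C(C#N)C#N)cc1` relates to compound 2 by methoxy in place of hydrogen on an aromatic carbon. This is the same kind of change as that from compound 1 to compound 3, not the same change: there the methoxy enters on a six-membered aromatic ring of carbon only that is part of a fused or bridged system of two rings, meta to a fused ring and para to a fused ring, whereas here it enters on a six-membered aromatic ring of carbon only, para to a large group, so that a phenyl becomes a 4-methoxyphenyl. Since compound 3 stayed close to compound 1, as the step of a 1.1-fold higher number from compound 1 to compound 3 (0.03 log units; within the scatter) shows, the expected step from compound 2 to compound 4 is a 1.1-fold higher number from compound 2 to compound 4 (0.05 log units; within the scatter), with the different ring setting adding some uncertainty. Compound 4 is therefore estimated at 4000 nM in this assay, expected to fall between 1800 nM and 9000 nM.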

Compound 4, concentration for 50% growth inhibition: 579 nM
The estimate for compound 4 lay 6.9-fold (0.84 log units) above the measured number, outside the stated range (below it).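

In this assay, putting methoxy in place of hydrogen on an aromatic carbon gave a 6.2-fold lower number from compound 2 to compound 4 (0.79 log units; beyond the scatter), a clear gain in growth inhibition for a change that had done almost nothing on the other core. Set beside the earlier step, the new one does not match it, so the size of the step did not carry over from one core to the other: the same change on two cores in this assay, a 1.1-fold higher number (0.03 log units; within the scatter) from compound 1 to compound 3 and a 6.2-fold lower number (0.79 log units; beyond the scatter) from compound 2 to compound 4, 6.6-fold (0.82 log units) apart, beyond the scatter of two such steps. What this does not show is the reason for the mismatch, since the two steps differ in more than one way: here a phenyl becomes a 4-methoxyphenyl, the earlier methoxy entered on a different ring, and the rest of the two cores also differs, so the setting of the methoxy and the core cannot be told apart.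

The compounds shown leave open how a plain phenyl in place of the 4-methoxyphenyl would read on the core of compound 1, a comparison that would test the same change in the same ring setting on the second core. They also leave open whether another group in the place of this methoxy, such as an amine or the longer ethoxy chain, would give a step of similar size from compound 2.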